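Sulfonyl substituent series: the step to compound 4

The source may hold more compounds than are shown below. What is called first, only, known or untested is meant among the compounds shown, and "the series" means these compounds.

- compound 1 `O=C(NCc1ccc(S(=O)(=O)c2cccc(C(F)(F)F)c2)cc1)N1Cc2ccncc2C1`: 10000 nM
- compound 2 `CC(C)n1cc(S(=O)(=O)c2ccc(CNC(=O)N3Cc4ccncc4C3)cc2)cn1`: 192000 nM
- compound 3 `O=C(NCc1ccc(S(=O)(=O)C2CCN(C3COC3)CC2)cc1)N1Cc2ccncc2C1`: 121000 nM

All three values come from a physicochemical assay for solubility, in phosphate buffer, with a stated time of 24 h, at pH 7.4, tested at 100 uM (on this read-out higher numbers stand for higher solubility and lower numbers for lower solubility), and fall on two levels. Compound 3 stands with compound 2 on the upper level, and a 1.6-fold lower number from compound 2 to compound 3 (0.20 log units; within the scatter) is the gap between them. Compound 1 lies far lower, and a 12-fold higher number from compound 1 to compound 3 (1.08 log units; beyond the scatter) measures that distance.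

The change now in view is 4-hydroxypiperidin-1-yl in place of 1-(oxetan-3-yl)piperidin-4-yl on a sulfonyl sulfur and it leads to compound 4 `O=C(NCc1ccc(S(=O)(=O)N2CCC(O)CC2)cc1)N1Cc2ccncc2C1` with 4-hydroxypiperidin-1-yl in place of 1-(oxetan-3-yl)piperidin-4-yl on a sulfonyl sulfur.

The step of a 19-fold higher number from compound 1 to compound 2 (1.28 log units; beyond the scatter) and the step of a 12-fold higher number from compound 1 to compound 3 (1.08 log units; beyond the scatter) are both large, but both leave 3-(trifluoromethyl)phenyl, a group that plays no part in this change. The nearer guide is a 1.6-fold lower number from compound 2 to compound 3 (0.20 log units; within the scatter) as an exchange that also does not involve that group. For the measured compounds named here, no measured compound carries 4-hydroxypiperidin-1-yl, so this guide is loose.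

In this assay no step beyond the scatter is therefore expected, and the estimated change is a 1.3-fold lower number from compound 3 to compound 4 (0.13 log units; within the scatter) as a working figure. For compound 4 the estimated value is 90000 nM with an expected range from 35000 nM to 190000 nM for now.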

Compound 4, solubility: 174000 nM
Compound 4: middle estimate off by 1.9-fold (0.29 log units), on the low side; the measured number falls inside the stated range.
By their numbers in this assay, from the lowest: compound 1; then compounds 3, 4 and 2 (each within the scatter of the next).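

In this assay, 4-hydroxypiperidin-1-yl on the sulfonyl sulfur sits on the same upper level as the two groups already there, with a 1.4-fold higher number from compound 3 to compound 4 (0.16 log units; within the scatter) and a 1.1-fold lower number from compound 2 to compound 4 (0.04 log units; within the scatter). The exchange from compound 3 removes the four-membered non-aromatic ring, going from 10 heavy atoms to 7 heavy atoms and from 0 hydrogen-bond donors to 1 hydrogen-bond donor, yet the read-out stays within the scatter, so this position tolerates that much change in these compounds without a measurable step. Three different groups now share the upper level and compound 1, with 3-(trifluoromethyl)phenyl, remains the only one apart, as a 17-fold higher number from compound 1 to compound 4 (1.24 log units; beyond the scatter) shows, which makes it the single outlier in this set rather than one end of a graded series.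

Still open, as far as these compounds go, is whether plain piperidin-1-yl without the hydroxyl, a carboxylic acid-bearing ring or a longer alkyl chain on the sulfonyl sulfur would stay on the upper level or fall toward compound 1. Nothing at hand bears on why these three groups sit together while compound 1 lies so far from them.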